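Fluorophenyl sulfone series: third fluorine isomer on the sulfonyl arene

The source may hold more compounds than are shown below. What is called first, only, known or untested is meant among the compounds shown, and "the series" means these compounds.

Compound 1 `O=S(=O)(c1ccccc1F)c1cn(C2CCNC2)c2ncccc12` and compound 2 `O=S(=O)(c1cccc(F)c1)c1cn(C2CCNC2)c2ncccc12` share one core and differ only in the fluorophenyl group on the sulfonyl sulfur. In an assay on HeLa cells for displacement of a labelled ligand from 5-hydroxytryptamine receptor 6 (Homo sapiens) (a higher number here means a weaker inhibitor, a lower number a stronger inhibitor), compound 1 gives 2 nM, and compound 2 gives 2.7 nM. Within the data shown here, the single measured step, a 1.4-fold higher number from compound 1 to compound 2 (0.13 log units; within the scatter), shows that compound 2 stands alongside compound 1, the two numbers lying within the scatter of each other; no further comparison is available.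

Compound 3 `O=S(=O)(c1ccc(F)cc1)c1cn(C2CCNC2)c2ncccc12` introduces the change (4-fluorophenyl in place of 3-fluorophenyl on a sulfonyl sulfur), the two structures having the same atoms joined differently. Among the measured compounds shown here, the only measured step that bears on this move is a 1.4-fold higher number from compound 1 to compound 2 (0.13 log units; within the scatter), which stayed within the scatter. On that basis no shift beyond the scatter is expected from the new fluorine placement, and no direction can be assigned.

Compound 3 is therefore expected to give about 3.5 nM, in a range from 1.5 nM to 9 nM. The expected step is a 1.3-fold higher number from compound 2 to compound 3 (0.11 log units; within the scatter).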

Compound 3, inhibition constant: 8.5 nM
The estimate for compound 3 lay 2.4-fold (0.39 log units) below the measured number, and the stated range covers the measured number.
By their numbers in this assay, from the lowest: compounds 1 and 2 (each within the scatter of the next); then compound 3.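

In this assay the placement of fluorine on the phenyl group on the sulfonyl sulfur now has a readable effect: 4-fluorophenyl in place of 3-fluorophenyl gives a 3.1-fold higher number from compound 2 to compound 3 (0.50 log units; beyond the scatter) and 4-fluorophenyl in place of 2-fluorophenyl gives a 4.3-fold higher number from compound 1 to compound 3 (0.63 log units; beyond the scatter). Both steps are modest, yet they make compound 3 the weakest of these three isomers, while compound 1 and compound 2 remain within the scatter of each other. No measurement shown accounts for this difference between the fluorine isomers.

As far as these compounds go, all three compounds carry a single fluorine on this phenyl group, so whether an unsubstituted phenyl, a chlorophenyl or a methoxyphenyl on the sulfonyl sulfur would fit this picture stays open. Also open, from the compounds shown here alone, is whether the same order among the fluorine isomers would hold on a different core.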